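Swapping a Halogenated Phenyl for an Ethylphenyl

The source may hold more compounds than are shown below. What is called first, only, known or untested is meant among the compounds shown, and "the series" means these compounds.

Compound 1 `COc1ccc(CN(C(=O)Nc2ccc(F)c(Cl)c2)n2cnnc2)cc1OC` and compound 2 `Cc1ccsc1CN(C(=O)Nc1ccc(Cl)c(C(F)(F)F)c1)n1cnnc1` are built on the shared core. In a functional assay on B16-F10 cells (Mus musculus) for cytotoxicity, read by MTT assay, with a stated time of 48 h (on this read-out lower numbers stand for stronger inhibition and higher numbers for weaker inhibition), compound 1 gives 20700 nM, and compound 2 gives 22100 nM; the two numbers lie within the usual scatter of each other, so neither one stands apart. Compound 3 `CCc1ccc(NC(=O)N(Cc2ccc(OC)c(OC)c2)n2cnnc2)cc1` differs from compound 1 in one place: 4-ethylphenyl in place of 3-chloro-4-fluorophenyl on an amide-type nitrogen. Going by the values given here, no measured pair shows this particular change, so its effect is not known. The step of a 1.2-fold higher number from compound 1 to compound 3 (0.08 log units; within the scatter) is expected to be small, with no clear direction beyond the scatter. Compound 3 is therefore estimated at 25000 nM, with a range from 8000 nM to 75000 nM.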

Compound 3, half-maximal inhibitory concentration: 22900 nM
Compound 3: middle estimate off by 1.1-fold (0.04 log units), on the high side; the measured number falls inside the stated range.
By their numbers in this assay, from the lowest: compounds 1, 2 and 3 (each within the scatter of the next).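

In this assay, putting 4-ethylphenyl in place of 3-chloro-4-fluorophenyl on an amide-type nitrogen gives a 1.1-fold higher number from compound 1 to compound 3 (0.04 log units; within the scatter) and so no change beyond the scatter. In this one pair, then, an ethyl group can take the place of both halogens on the aromatic ring without moving the number beyond the scatter. Nothing measured here tells why the two groups read alike. Still open, on these data alone, is whether any group at this position can shift the number beyond the scatter. A phenyl ring carrying an amine or a carboxylic acid, or a longer chain such as hexyl, is not among the compounds shown.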